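Chloro for methyl on the core of compound 1

A few compounds are considered here, and "the series" means these few. Any claim that something is new, unique, unknown or untested is made for them only; others in the source may bear on it.

Measured so far:
compound 1 `COc1cc(C)nc2n/c(=N/C(=O)c3c(-c4ccc(Cl)cc4Cl)noc3C)sn12` gives 50.3% in a functional assay on the whole organism for inhibition, with Digitaria ciliaris as the target, with a stated time of 72 h, tested at 10 mg/L; a higher number here means more inhibition of growth at the concentration tested, a lower number less inhibition of growth
compound 2 `CSc1cc(C)nc2n/c(=N/C(=O)c3c(-c4ccc(Cl)cc4Cl)noc3C)sn12` gives 26.8% in this assay

Going by the values given here, compound 1 stands highest of the two numbers; the single step, a number 23.5 percentage points lower from compound 1 to compound 2 (beyond the scatter), goes down and lies beyond the scatter. Compound 3 `COc1cc(Cl)nc2n/c(=N/C(=O)c3c(-c4ccc(Cl)cc4Cl)noc3C)sn12` differs from compound 1 by chloro in place of methyl on an aromatic carbon. Among the compounds with values here, the measured step concerns a different group at another place, so no step bears on this change, and there is no basis for expecting a shift beyond the scatter. The expected step is a number 2.3 percentage points lower from compound 1 to compound 3 (within the scatter). Compound 3 is therefore estimated at 48% in this assay, with a range from 20% to 76%.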

Compound 3, percent growth inhibition at one concentration: 16.5%
Beside the measured number, compound 3's estimate is 31.5 percentage points above it; measured number below the stated range.
By their numbers in this assay, from the lowest: compound 3; then compound 2; then compound 1.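

In this assay, chloro in place of methyl gives a number 33.8 percentage points lower from compound 1 to compound 3 (beyond the scatter), so this position on the core is not indifferent to what it carries. The earlier compounds had shown a change only at the methoxy group; now a second place on the same six-membered aromatic ring also moves growth inhibition. Nothing available accounts for this drop. From the compounds shown here alone, it remains open whether the loss belongs to chloro itself or to any departure from methyl, and how an amine or an ethyl group would fare here.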